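The source may report more compounds than this note shows. Statements on the series, on what has been measured and on what is new or still open speak of the compounds shown alone.

Measured so far:
- Compound 1, `CN(CCCN1CCCCC1)c1ccc(C(=O)N2CCc3ccc(OS(N)(=O)=O)cc3C2)cc1`, gives 40.7% in an assay on HEK293 cells for inhibition of Steryl-sulfatase (Homo sapiens), tested at 1 uM; on this read-out higher numbers stand for a stronger effect at the one concentration tested and lower numbers for a weaker effect.
- Compound 2, `CCCN(CCC)c1cccc(C(=O)N2CCc3ccc(OS(N)(=O)=O)cc3C2)c1`, gives 54.8% in the same assay.

Within the data shown here, compound 2 holds the higher of the two numbers known in this assay; its nearest neighbour, compound 1, lies a distance below it that exceeds the usual scatter. Among the measured compounds shown here, no single-change step between the measured compounds is available, so no measured step sets the scale. Compound 3, `CN(CCCN1CCCCC1)c1cccc(C(=O)N2CCc3ccc(OS(N)(=O)=O)cc3C2)c1`, has not yet been tested. It differs from compound 2 in one place: methyl(3-(piperidin-1-yl)propyl)amino in place of dipropylamino on an aromatic carbon. Because compound 1, which carries the same entering group, gives 40.7%, the change is expected to pull the number down rather than up, though by a modest amount. Compound 3 is expected to give 45%, between 27% and 63%, the expected step from compound 2 being a number 9.8 percentage points lower from compound 2 to compound 3 (within the scatter).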

Compound 3, a percentage reported as inhibition, at one concentration (the size of the read-out at that concentration, not a potency): 30.6%
For compound 3 the middle estimate is 14.4 percentage points above the measured one, within the range that was stated.
By their numbers in this assay, from the lowest: compound 3; then compound 1; then compound 2.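

In this assay, placing methyl(3-(piperidin-1-yl)propyl)amino instead of dipropylamino on this aromatic carbon gives a number 24.2 percentage points lower from compound 2 to compound 3 (beyond the scatter). Among these compounds, this is the first single-change step in the set, and it shows that the effect at the one concentration tested depends on which amino group occupies this position. The step applies only to this exchange on the shared core, and nothing measured here accounts for it.

The exchange alters several features at once, adding a six-membered non-aromatic ring and a second nitrogen, so the compounds shown do not separate the contribution of the ring from that of the rest of the group. As far as these compounds go, it remains open how a smaller group such as dimethylamino, or a propyl chain ending in morpholine, would read at this position.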